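Amine Swap on a Thiocarbonyl Carbon Across Two Cores

A few compounds are considered here, and "the series" means these few. Any claim that something is new, unique, unknown or untested is made for them only; others in the source may bear on it.

Four compounds share a thiocarbonyl carbon that carries a sulfur on one side and an amine on the other, and they differ in that amine and in the core behind it. Compound 1 `CC(C)N(C(=S)SCc1cc(=O)c2ccc(Cl)cc2o1)C(C)C` and compound 2 `O=c1cc(CSC(=S)N2CCOCC2)oc2cc(Cl)ccc12` sit on one core; compound 3 `Cc1ccc2c(=O)c(CSC(=S)N(C(C)C)C(C)C)coc2c1` and the still unmeasured compound 4 `Cc1ccc2c(=O)c(CSC(=S)N3CCOCC3)coc2c1` sit on another. The difference between the two cores is not broken down here.

In a functional assay on HeLa cells (Homo sapiens) for antiproliferative activity, read by MTT assay, with a stated time of 72 h (on this read-out lower numbers stand for stronger inhibition and higher numbers for weaker inhibition), compound 1 gives only a limit, > 30000 nM, which is a boundary of the measurement and not a number. Compound 2 gives 33300 nM in this assay. The change between these two, (morpholin-4-yl in place of diisopropylamino on a thiocarbonyl carbon), therefore yields a step whose size cannot be read: a step that the limit leaves unreadable from compound 1 to compound 2. This limit, (the limit of > 30000 nM in this assay, at which 1 of the 3 values shown sits), is the reason the step stays unreadable. Compound 3 gives 1400 nM in this assay, the lowest number among the measured compounds.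

Compound 4 carries the same kind of change as compound 2 does, on the other core: morpholin-4-yl in place of diisopropylamino on a thiocarbonyl carbon. Because the step that the limit leaves unreadable from compound 1 to compound 2 cannot be sized, it offers no measured guide for this assay, so the expected step of a 3.6-fold higher number from compound 3 to compound 4 (0.55 log units; beyond the scatter) is a cautious guess toward a weaker result, resting on compound 3 at 1400 nM as the only anchor. Compound 4 is therefore estimated at 5000 nM, with a wide expected range from 1500 nM to 25000 nM.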

Compound 4, half-maximal inhibitory concentration: 6100 nM
Estimate against measurement, compound 4: 1.2-fold (0.09 log units) below, within the range that was stated.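

On the core of compound 3, putting morpholin-4-yl in place of diisopropylamino on a thiocarbonyl carbon can be sized in this assay, and it gives a 4.4-fold higher number from compound 3 to compound 4 (0.64 log units; beyond the scatter). Compound 1 gives only a limit, > 30000 nM, which is a boundary of the measurement and not a number. This shows the direction and size of the change on one core only and does not show that the same change has a similar direction or size on the other core, since the step on that core cannot be read because of this limit: the limit of > 30000 nM in this assay, at which 1 of the 4 values shown sits.

The compounds shown carry only two amines on the thiocarbonyl carbon, so it remains open how piperidin-1-yl, a six-membered ring with no oxygen, would read in this assay, and whether that ring would fall nearer to morpholin-4-yl or to diisopropylamino. Also open, going by these compounds, is how a smaller open-chain amine such as dimethylamino would read on either core, which would show whether the result follows the ring or the particular amine.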